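This account rests on a few compounds, and the source may have more. Where it says the series, first, only, none or still open, it means among the compounds named here.

Measured so far:
- compound 1 `Cc1cccc(Cn2cc(COc3ccc4c(=O)ccoc4c3)nn2)c1`, 11700 nM
- compound 2 `CC(C)(C)c1ccc(Cn2cc(COc3ccc4c(=O)ccoc4c3)nn2)cc1`, 28800 nM

In a functional assay on SW480 cells (Homo sapiens) for cytotoxicity, read by MTT assay, with a stated time of 48 h (a lower number here means a stronger inhibitor, a higher number a weaker inhibitor), compound 2 gives the highest of the two numbers; its nearest neighbour, compound 1, gives a lower value, and that gap lies beyond the scatter. Compound 3 `N#Cc1ccc(Cn2cc(COc3ccc4c(=O)ccoc4c3)nn2)cc1` has not yet been measured. It differs from compound 2 by cyano in place of tert-butyl on an aromatic carbon. Going by the values given here, no measured pair shows the effect of this change, so the author expects only a small step, if any, and a slight move toward a lower number for compound 3 is estimated, a 1.4-fold lower number from compound 2 to compound 3 (0.16 log units; within the scatter). For compound 3 the estimate in this assay is 20000 nM, within the range 7000 nM to 60000 nM.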

Compound 3, half-maximal inhibitory concentration: > 100000 nM
Compound 3 was reported as a limit; the forecaster's own chance of this, stated with the estimate: 10%; middle value at least 5.0-fold (0.69 log units) from the limit.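

In this assay compound 3 gives > 100000 nM, which is a limit of the assay and not a number. Even so, cyano in place of tert-butyl on this aromatic carbon is no neutral change, giving an at least 3.4-fold higher number from compound 2 to compound 3 (0.54 log units; beyond the scatter), while 4-cyanophenyl in place of 3-methylphenyl gives an at least 8.5-fold higher number from compound 1 to compound 3 (0.93 log units; beyond the scatter). A single change at this position can thus carry the result out of the measured range: the limit of > 100000 nM in this assay, at which 1 of the 3 values shown sits.

On these data alone, the true size of both steps stays open. So does what an amine or a carboxylic acid on this aromatic carbon would give.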